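From acetyl to vinylcarbonyl on a shared core

A few compounds are considered here, and "the series" means these few. Any claim that something is new, unique, unknown or untested is made for them only; others in the source may bear on it.

Three compounds have been measured in an assay on cells for antagonist activity at transient receptor potential cation channel subfamily V member 1 (Homo sapiens), read by FLIPR and calcium flux, with a stated time of 15 min; on this read-out higher numbers stand for weaker inhibition and lower numbers for stronger inhibition:

compound 1, `CCS(=O)(=O)Nc1ccc(C(C)C(=O)NCc2ccc(C(F)(F)F)nc2N2CCC(C)CC2)cc1F`, with 4.4 nM
compound 2, `CC1CCN(c2nc(C(F)(F)F)ccc2CNC(=O)C(C)c2ccc(NS(=O)(=O)C(C)C)c(F)c2)CC1`, with 8.7 nM
compound 3, `CC(=O)N(c1ccc(C(C)C(=O)NCc2ccc(C(F)(F)F)nc2N2CCC(C)CC2)cc1F)S(C)(=O)=O`, with 11.9 nM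

Compound 3 has the highest number of the three in this assay. Its nearest neighbour is compound 2: a 1.4-fold higher number from compound 2 to compound 3 (0.14 log units; within the scatter). The gap to compound 1 is larger: a 2.7-fold higher number from compound 1 to compound 3 (0.43 log units; beyond the scatter). The step between compound 1 and compound 2 is also small: a 2.0-fold higher number from compound 1 to compound 2 (0.30 log units; within the scatter). All three measured steps alter the group on the aromatic carbon, exchanging one sulfonyl substituent for another or adding an acetyl to the nitrogen, and all stay within a modest span.

Compound 4, `C=CC(=O)N(c1ccc(C(C)C(=O)NCc2ccc(C(F)(F)F)nc2N2CCC(C)CC2)cc1F)S(C)(=O)=O`, has not been measured. Relative to compound 3 the difference is vinyl in place of methyl on a carbonyl carbon. Within the data shown here, no measured step changes the substituent on this carbonyl carbon; the nearest comparisons, compound 2 to compound 3 and compound 1 to compound 3, alter the neighbouring sulfonyl or acetyl groups and show small or modest steps. The step from compound 3 to compound 4 is therefore expected to be small, with no clear direction beyond the scatter: a 1.1-fold higher number from compound 3 to compound 4 (0.04 log units; within the scatter). Compound 4 is estimated at 13 nM in this assay, with a likely range from 5 nM to 35 nM.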

Compound 4, inhibition constant: 2.4 nM
Estimate against measurement, compound 4: 5.4-fold (0.73 log units) above, outside the stated range (below it).
By their numbers in this assay, from the lowest: compounds 4, 1, 2 and 3 (each within the scatter of the next, the first and the last beyond it).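

In this assay, the substituent on the carbonyl carbon turns out to matter, a point the earlier compounds could not show because none of them varied it: vinyl in place of methyl gives a 5.0-fold lower number from compound 3 to compound 4 (0.70 log units; beyond the scatter), the largest step among the compounds shown. The (methylsulfonyl)(vinylcarbonyl)amino group also separates from (isopropylsulfonyl)amino, with a 3.6-fold lower number from compound 2 to compound 4 (0.56 log units; beyond the scatter), whereas its exchange for (ethylsulfonyl)amino gives a 1.8-fold lower number from compound 1 to compound 4 (0.26 log units; within the scatter), so a group with no hydrogen left on this nitrogen can match the simple (ethylsulfonyl)amino group once it carries vinyl rather than methyl. Nothing among the data shown explains why vinyl and methyl differ at this position.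

Going by these compounds, it remains open whether the change depends on the double bond or simply on the larger group, a question that an ethyl on the same carbonyl carbon would help to settle, as would a cyclopropyl or a longer chain. On these data alone, it is also open whether vinyl on this carbonyl carbon would give a similar step with ethylsulfonyl or isopropylsulfonyl in place of methylsulfonyl on the same nitrogen.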